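The source may report more compounds than this note shows. Statements on the series, on what has been measured and on what is new or still open speak of the compounds shown alone.

Three compounds sharing the core of compound 1 `O=c1cc(/C=N\c2ccccc2O)c2c(OCc3ccccc3)cc(OCc3ccccc3)cc2o1` have been tested in a functional assay, read by spectrophotometry, with a stated time of 5 min; a lower number here means a stronger inhibitor, a higher number a weaker inhibitor. Compound 1 gives 33100 nM, the lowest of the three numbers and thus the strongest inhibition among them. Compound 3 `N/N=C\c1cc(=O)oc2cc(OCc3ccccc3)ccc12` gives 131000 nM in this assay, and compound 2 `O=c1cc(/C=N\Nc2ccc([N+](=O)[O-])cc2[N+](=O)[O-])c2ccc(OCc3ccccc3)cc2o1` gives 181000 nM; both gaps from compound 1 lie beyond the scatter. Compound 4 `O=c1cc(/C=N\Nc2ccc([N+](=O)[O-])cc2)c2c(OCc3ccccc3)cc(OCc3ccccc3)cc2o1` has not yet been measured. It differs from compound 1 by (4-nitrophenyl)amino in place of 2-hydroxyphenyl on a double-bonded nitrogen. Within the data shown here, no measured pair isolates this change, but compound 2, which also carries nitro groups, gives 181000 nM, a weaker result than compound 1. A step towards weaker inhibition is expected, so compound 4 is estimated at 80000 nM, within 30000 nM to 250000 nM. The expected step from compound 1 to compound 4 is a 2.4-fold higher number from compound 1 to compound 4 (0.38 log units; beyond the scatter).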

Compound 4, half-maximal inhibitory concentration: 419000 nM
Beside the measured number, compound 4's estimate is 5.2-fold (0.72 log units) below it; the whole stated range lies below it.
By their numbers in this assay, from the lowest: compound 1; then compounds 3 and 2 (each within the scatter of the next); then compound 4.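

Putting (4-nitrophenyl)amino in place of 2-hydroxyphenyl on a double-bonded nitrogen gives a 13-fold higher number from compound 1 to compound 4 (1.10 log units; beyond the scatter) in this assay. This first single-place comparison shows that inhibition depends strongly on the group held at this place, with the rest of compound 1 unchanged. Nothing available explains the size of this step.

The pair cannot separate the loss of 2-hydroxyphenyl from the arrival of (4-nitrophenyl)amino. A plain phenylamino group at this place would show how much of the step goes with the nitro group.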